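Hexyloxy to (but-3-en-1-yl)oxy in the series

The source may report more compounds than this note shows. Statements on the series, on what has been measured and on what is new or still open speak of the compounds shown alone.

In a functional assay on LoVo cells (Homo sapiens) for inhibition, read by colorimetric assay and MTT assay, with a stated time of 72 h (on this read-out lower numbers stand for stronger inhibition and higher numbers for weaker inhibition), compound 1 `C=CCCCCOc1ccccc1-c1cnc(OCCC=C)n1C` gives 12000 nM and compound 2 `C=CCCCCOc1cc2ccccc2cc1-c1cnc(OCCCCC=C)n1C` gives 25000 nM on the same scale. Compound 3 `CCCCCCOc1ncc(-c2ccccc2OC)n1C` gives 27000 nM in this small set. That places it level with compound 2 within the scatter and beyond the scatter from compound 1, whose number is lower.

Compound 4 `C=CCCOc1ncc(-c2ccccc2OC)n1C` keeps the core of compound 3 and alters only the ether chain, with vinyl in place of butyl on a saturated chain carbon, two bonds along the chain from an oxygen on an aromatic ring as the counted change. The same difference reads hexyloxy to (but-3-en-1-yl)oxy.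

Going by the values given here, no two measured compounds differ in one place, so the series offers no direct step for this change. Compound 1 carries the same (but-3-en-1-yl)oxy group at 12000 nM but differs elsewhere too, which makes it only a weak hint towards a lower number. In this assay a slightly lower number is expected, with no step beyond the scatter. The estimated step of a 1.2-fold lower number from compound 3 to compound 4 (0.09 log units; within the scatter) is expected to remain small. For compound 4 the estimate is 22000 nM with an expected range from 10000 nM to 60000 nM in this read-out.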

Compound 4, half-maximal inhibitory concentration: 24000 nM
For compound 4 the middle estimate is 1.1-fold (0.04 log units) below the measured one; measured number inside the range.
By their numbers in this assay, from the lowest: compounds 1, 4, 2 and 3 (each within the scatter of the next, the first and the last beyond it).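

In this assay, going by these compounds alone, a 1.1-fold lower number from compound 3 to compound 4 (0.05 log units; within the scatter) gives the first direct reading of this ether chain: vinyl in place of butyl on a saturated chain carbon, two bonds along the chain from an oxygen on an aromatic ring, stays within the scatter. The second reading, a 2.0-fold higher number from compound 1 to compound 4 (0.30 log units; within the scatter), also stays within the scatter, with hydrogen in place of pent-4-en-1-yl on a saturated chain carbon bound to an oxygen on an aromatic ring. The earlier compounds shown here offered no single-place step, whereas compound 4 now links to compound 3 and compound 1, and neither of these two changes moves the number beyond the scatter. No measurement here bears on why these steps remain small.

The compounds shown leave open whether an amine or a carboxylic acid in place of the hexyloxy group would give a step beyond the scatter. Also open, as far as these compounds go, is whether a longer chain in that place would do so, since all the single-place readings so far involve only the unsubstituted hydrocarbon chains named above.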